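Triazene series: from trifluoromethyl to nitro

The source may hold more compounds than are shown below. What is called first, only, known or untested is meant among the compounds shown, and "the series" means these compounds.

Values in an ADME assay on MT4 cells (Homo sapiens) for cytotoxicity, read by MTT assay, with a stated time of 96 h; on this read-out higher numbers stand for lower toxicity in this test and lower numbers for higher toxicity in this test:
- Compound 1 `Clc1cccc(/N=N/N2CCCC2)c1`: > 100000 nM (a limit)
- Compound 2 `c1ccc(/N=N/c2ccc(NC[C@@H]3CCCN4CCCC[C@H]34)c3c2CCCC3)cc1`: 100000 nM
- Compound 3 `FC(F)(F)c1cccc(/N=N/N2CCCC2)c1`: > 100000 nM (a limit)

Compound 3 reads > 100000 nM, which is a limit of the assay and not a number. Going by the values given here, the same ceiling dominates the series so far, with the limit of > 100000 nM in this assay, at which 2 of the 3 values shown sit.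

Compound 4 `O=[N+]([O-])c1cccc(/N=N/N2CCCC2)c1` carries nitro in place of trifluoromethyl on an aromatic carbon, and the counted difference is nitro in place of trifluoromethyl on an aromatic carbon.

Among the compounds with values here, the one measured step that bears on this change is a step that the two limits leave unreadable from compound 1 to compound 3. It also concerns the same aromatic carbon, but it gives no size to carry over. Only a modest move, or none that can be read, is therefore expected in this assay. With compound 3 reading > 100000 nM, any readable step would have to run toward lower numbers. The expected step is an at least 1.1-fold lower number from compound 3 to compound 4 (0.07 log units; that floor lies within the scatter). For compound 4 the estimated value is 85000 nM, with an expected range from 35000 nM to 100000 nM.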

Compound 4, half-maximal cytotoxic concentration: 66000 nM
Beside the measured number, compound 4's estimate is 1.3-fold (0.11 log units) above it; measured number inside the range.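

On this aromatic carbon, compound 4 with nitro gives a readable number in this assay, whereas compound 1 and compound 3 stand only as limits of the assay. The change to nitro gives an at least 1.5-fold lower number from compound 3 to compound 4 (0.18 log units; that floor lies within the scatter), and the change from chloro gives an at least 1.5-fold lower number from compound 1 to compound 4 (0.18 log units; that floor lies within the scatter); these are floors, so the full size of either step is not fixed. The step between the two limited compounds cannot be read, and the ceiling still covers much of the series: the limit of > 100000 nM in this assay, at which 2 of the 4 values shown sit.

Neither floor shows a step beyond the usual scatter, so a real separation of nitro from trifluoromethyl or chloro remains unestablished. From the compounds shown here alone, how an amine or a carboxylic acid on the same aromatic carbon would read in this assay stays open, as does whether any group there moves the number clearly away from the ceiling.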